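Butoxycarbonyl to isobutoxycarbonyl: from compound 1 to compound 4

A few compounds are considered here, and "the series" means these few. Any claim that something is new, unique, unknown or untested is made for them only; others in the source may bear on it.

Compound 1 `CCCCOC(=O)Nc1ccc(S(=O)(=O)N2C[C@H](c3ccccc3)NC2=O)cc1CC` is the reference point of the series. In a functional assay on HCT-116 cells (Homo sapiens) for cytotoxicity, read by MTT assay (on this read-out lower numbers stand for stronger inhibition and higher numbers for weaker inhibition), compound 1 gives 200 nM. Compound 2 `CCOC(=O)Nc1ccc(S(=O)(=O)N2C[C@H](c3ccccc3)NC2=O)cc1Cl` stands level with it at the digits shown: in this assay compound 2 gives 200 nM. Compound 3 `CCOC(=O)Nc1c(C)cc(S(=O)(=O)N2C[C@H](c3ccccc3)NC2=O)cc1C` is different in kind, as in this assay compound 3 gives only > 10000 nM, which is a limit of the assay and not a number (the limit of > 10000 nM in this assay, at which 1 of the 3 values shown sits). Within the data shown here, no single-change step between measured compounds is available to calibrate the series.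

Compound 4 `CCc1cc(S(=O)(=O)N2C[C@H](c3ccccc3)NC2=O)ccc1NC(=O)OCC(C)C` keeps the same atoms as compound 1, joined differently: isopropyl in place of propyl on a saturated chain carbon bound to an oxygen next to a carbonyl group. The step from compound 1 to compound 4 is expected to be a 1.3-fold higher number from compound 1 to compound 4 (0.10 log units; within the scatter), no change beyond the scatter in either direction. Compound 4 is therefore estimated at 250 nM, with a range from 100 nM to 700 nM.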

Compound 4, half-maximal inhibitory concentration: 60 nM
Beside the measured number, compound 4's estimate is 4.2-fold (0.62 log units) above it; measured number outside the range, below it.
By their numbers in this assay, from the lowest: compound 4; then compounds 1 and 2 (each within the scatter of the next). At a limit, above all of these: compound 3.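

In this assay, isopropyl in place of propyl on a saturated chain carbon bound to an oxygen next to a carbonyl group gives a 3.3-fold lower number from compound 1 to compound 4 (0.52 log units; beyond the scatter). Among these compounds, this is the first single-change step, and with the atoms unchanged, the way the chain is joined is enough to move the number beyond the scatter. No measurement shown bears on why the branched chain gives the lower number.

Open, going by these compounds, is whether a tert-butyl or cyclopropylmethyl group in the same place lowers the number further or reverses the step. Also open, on these data alone, is whether the butoxycarbonyl to isobutoxycarbonyl change gives a similar step on the core of compound 2.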